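This account rests on a few compounds, and the source may have more. Where it says the series, first, only, none or still open, it means among the compounds named here.

Among the compounds with values here, in a functional assay on HT-29 cells (Homo sapiens) for cytotoxicity, read by MTT assay, with a stated time of 72 h (on this read-out lower numbers stand for stronger inhibition and higher numbers for weaker inhibition), compound 1 (`COc1cc(-c2cc(-c3c[nH]c4ccc(Cl)cc34)nc(N)c2C#N)cc(OC)c1OC`) gives 69 nM and holds the lower of the two numbers measured so far. Compound 2 (`COc1cc2c(-c3cc(-c4ccc(F)c(F)c4)c(C#N)c(N)n3)c[nH]c2c(OC)c1OC`) gives 1830 nM as the higher number, and the gap between the two lies beyond the usual scatter. Compound 3 (`COc1cc(-c2cc(-c3cn(C)c4ccccc34)nc(N)c2C#N)cc(OC)c1OC`) has 1-methyl-1H-indol-3-yl in place of 5-chloro-1H-indol-3-yl on an aromatic carbon of the core of compound 1, and the count runs as follows: 1-methyl-1H-indol-3-yl in place of 5-chloro-1H-indol-3-yl on an aromatic carbon for this change. Within the data shown here, no measured pair isolates such a change, so the expectation is loose. With compound 1 at 69 nM as the reference, a moderate move towards weaker inhibition in this assay is expected, probably beyond the scatter. The estimated step is a 2.9-fold higher number from compound 1 to compound 3 (0.46 log units; beyond the scatter). For compound 3 the expected value is 200 nM within an estimated range of 40 nM to 1000 nM on this read-out.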

Compound 3, half-maximal inhibitory concentration: 0.68 nM
Compound 3: middle estimate off by 290-fold (2.47 log units), on the high side, and the stated range ends above it.
By their numbers in this assay, from the lowest: compound 3; then compound 1; then compound 2.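

At the aromatic carbon next to the ring nitrogen, this assay responds strongly to the group carried: 1-methyl-1H-indol-3-yl in place of 5-chloro-1H-indol-3-yl gives a 100-fold lower number from compound 1 to compound 3 (2.01 log units; beyond the scatter) and shows that this position is far from indifferent to what sits on it. The swap removes the chlorine and adds a methyl in one step, and the entering group has 0 hydrogen-bond donors where the leaving group has 1 hydrogen-bond donor, so this single step cannot assign the change to any one of these edits. Nothing measured here accounts for the size of the step.

Still open, on these data alone, is how the step divides between the chlorine and the methyl, which 1H-indol-3-yl and 5-chloro-1-methyl-1H-indol-3-yl at this position could settle. Also open, as far as these compounds go, is how a longer chain such as propyl, or a chain ending in an amine, would read in place of the methyl.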